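This account rests on a few compounds, and the source may have more. Where it says the series, first, only, none or still open, it means among the compounds named here.

Among the values shown for an assay on isolated protein for activation of cGMP-dependent protein kinase 1 (Homo sapiens), read by ADP-Glo, with stated times of 30 min and 2 h (a higher number here means that more compound is needed for the effect, a lower number that less compound is needed), compound 3 `O=C(O)c1ccc(CN2CCC[C@H](O[C@H](CO)c3cc(Cl)cc(Cl)c3)[C@@H]2c2ccccc2)cc1` stands lowest of the two numbers: in this assay compound 3 gives 77000 nM. Its nearest neighbour is compound 2 `Nc1cc(C(=O)O)ccc1CN1CCC[C@H](O[C@H](CO)c2cc(Cl)cc(Cl)c2)[C@@H]1c1ccccc1`, for which this assay gives 168000 nM, and the step of a 2.2-fold lower number from compound 2 to compound 3 (0.34 log units; beyond the scatter) lies beyond the scatter. Compound 1 `OC[C@@H](O[C@H]1CCCN(Cc2ncc[nH]2)[C@H]1c1ccccc1)c1cc(Cl)cc(Cl)c1` is shown only as a limit of this assay, > 200000 nM, and the limit of > 200000 nM in this assay, at which 1 of the 3 values shown sits, describes that boundary.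

Compound 4 `OC[C@@H](O[C@H]1CCCN(Cc2nc3ccccc3[nH]2)[C@H]1c1ccccc1)c1cc(Cl)cc(Cl)c1` differs from compound 3 by 1H-benzimidazol-2-yl in place of 4-carboxyphenyl on a saturated chain carbon bound to an amine nitrogen in a ring. The step that bears on it most directly is an at least 2.5-fold lower number from compound 1 to compound 3 (0.41 log units; beyond the scatter), in which 4-carboxyphenyl replaced 1H-imidazol-2-yl; compound 4 carries a 1H-benzimidazol-2-yl group, which, like the group in compound 1, is a fused five-membered aromatic ring with two hetero atoms bound to the same saturated chain carbon. The step of an at least 1.1-fold lower number from compound 1 to compound 2 (0.07 log units; that floor lies within the scatter) is only a floor within the scatter and says little. Going from compound 3 to compound 4 reverses much of that change, so a move back towards the limit seen for compound 1 is expected, in the direction of a higher number, with a real chance that this assay again reports only a limit. The expected step is a 1.9-fold higher number from compound 3 to compound 4 (0.29 log units; within the scatter). For compound 4 the estimate in this assay is 150000 nM, between 60000 nM and 400000 nM.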

Compound 4, half-maximal effective concentration: > 200000 nM
Compound 4: no number, only a limit; the forecaster's own chance of this, stated with the estimate: 35%; middle value at least 1.3-fold (0.12 log units) from the limit.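

In this assay, replacing 4-carboxyphenyl with 1H-benzimidazol-2-yl on a saturated chain carbon bound to an amine nitrogen in a ring gives an at least 2.5-fold higher number from compound 3 to compound 4 (0.41 log units; beyond the scatter), although the two groups have the same number of heavy atoms. Among the four compounds, only compound 2 and compound 3, which carry a carboxyphenyl group, give a number, and none of the four goes against this pattern; the step of an at least 1.1-fold higher number from compound 2 to compound 4 (0.07 log units; that floor lies within the scatter), however, does not separate compound 4 from compound 2. Compound 1 and compound 4 both stand at a limit, so the step between them cannot be read, and the larger fused group cannot be ranked against 1H-imidazol-2-yl: the limit of > 200000 nM in this assay, at which 2 of the 4 values shown sit.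

The compounds shown leave open whether the carboxylic acid or the phenyl ring that carries it goes with the lower numbers, a question that a plain benzyl group or a primary amide in place of the carboxylic acid would address. They also leave open whether a carboxylic acid attached to the 1H-benzimidazol-2-yl group would bring a measurable number in this assay.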